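Benzimidazole amide series: cyclopropyl to oxolanyl at the amine

The source may hold more compounds than are shown below. What is called first, only, known or untested is meant among the compounds shown, and "the series" means these compounds.

Measured compounds:
compound 1 `CC(C)N(C)c1nc2ccc(NC(=O)c3cnc(-c4ccc(F)cc4)cn3)cc2[nH]1`, in an assay on CHO-K1 cells for displacement of a labelled ligand from melanin-concentrating hormone receptor 1 (Homo sapiens), read by scintillation counting (on this read-out lower numbers stand for stronger inhibition and higher numbers for weaker inhibition), compound 1 gives 2.7 nM.
compound 2 `CC(C)N(C)c1nc2ccc(NC(=O)CCc3ccc(C(F)(F)F)cc3)cc2s1`, in this assay compound 2 gives > 750 nM.
compound 3 `CN(c1nc2ccc(NC(=O)CCc3ccc(C(F)(F)F)cc3)cc2[nH]1)C1CC1`, in this assay compound 3 gives 24 nM.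

The value of compound 2 is a limit of the assay and not a number (the limit of > 750 nM in this assay, at which 1 of the 3 values shown sits). Among the two numbers that were read, compound 3 stands highest; compound 1 sits lower, and the gap between compound 1 and compound 3 lies beyond the usual scatter. Compound 1 and compound 3 differ in more than one place, so their gap cannot be assigned to any single change.

The next compound, compound 4 `CN(c1nc2ccc(NC(=O)CCc3ccc(C(F)(F)F)cc3)cc2[nH]1)C1CCOC1`, keeps the core and the amide side chain of compound 3 and changes only the amine substituent: oxolan-3-yl in place of cyclopropyl on a nitrogen on an aromatic ring. The change is oxolan-3-yl in place of cyclopropyl on a nitrogen on an aromatic ring. Going by the values given here, no measured pair in this set isolates a change of this kind, so there is no measured step to lean on.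

The expected step of a 1.7-fold higher number from compound 3 to compound 4 (0.22 log units; within the scatter) is small, not clearly beyond the scatter, with a slight lean toward a higher number. Compound 4 is expected to give about 40 nM, within a range from 12 nM to 150 nM in this assay.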

Compound 4, half-maximal inhibitory concentration: 27 nM
Beside the measured number, compound 4's estimate is 1.5-fold (0.17 log units) above it; the measured number falls inside the stated range.
By their numbers in this assay, from the lowest: compound 1; then compounds 3 and 4 (each within the scatter of the next). At a limit, above all of these: compound 2.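

In this assay, oxolan-3-yl in place of cyclopropyl on a nitrogen on an aromatic ring gives a 1.1-fold higher number from compound 3 to compound 4 (0.05 log units; within the scatter) and so stays within the scatter. Going by these compounds alone, this is the first measured step at this amine substituent, and it shows that the position takes a five-membered ring of 5 heavy atoms with 1 hydrogen-bond acceptor in place of a three-membered carbon ring of 3 heavy atoms with none, with no difference that can be told apart in this read-out. Nothing measured in this set accounts for the step, so the result stands here as an observation only.

This single step does not show how far the position stays flat, and an open-chain ether such as 2-methoxyethyl, a piperidin-4-yl ring carrying a ring amine, or a longer chain ending in a carboxylic acid would test that on the same nitrogen. As far as these compounds go, the gaps that link compound 1 or compound 2 to the other compounds cannot be read as single changes, so the separate contributions of the core and of the amide side chain remain open.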